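A few compounds are considered here, and "the series" means these few. Any claim that something is new, unique, unknown or untested is made for them only; others in the source may bear on it.

Measured so far in an ADME assay on RAW264.7 cells (Mus musculus) for cytotoxicity, read by MTT assay, with a stated time of 24 h; on this read-out lower numbers stand for higher toxicity in this test and higher numbers for lower toxicity in this test:
compound 1, `Cc1ccc(C2=NN(C3=NC(=O)CS3)C(c3ccccc3C)C2)cc1C`: 317000 nM
compound 2, `Cc1ccc(C2=NN(C3=NC(=O)CS3)C(c3cccc(Cl)c3)C2)cc1C`: 178000 nM
compound 3, `Cc1ccc(C2=NN(C3=NC(=O)CS3)C(c3ccc(Br)cc3)C2)cc1C`: 365000 nM

Compound 1 stands second highest of the three numbers; the nearest number is that of compound 3, the furthest that of compound 2. Going by the values given here, the step of a 1.2-fold higher number from compound 1 to compound 3 (0.06 log units; within the scatter) and the step of a 1.8-fold lower number from compound 1 to compound 2 (0.25 log units; within the scatter) both stay within the scatter; only the step of a 2.1-fold higher number from compound 2 to compound 3 (0.31 log units; beyond the scatter) goes beyond it, and only modestly. Among the compounds with values here, the three compounds share one core and differ only in the aryl group on the saturated ring carbon, so the whole spread of the series so far is small.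

Compound 4, `Cc1cccc(C2CC(c3ccc(C)c(C)c3)=NN2C2=NC(=O)CS2)c1`, differs from compound 1 by 3-methylphenyl in place of 2-methylphenyl on a saturated ring carbon. Within the data shown here, the steps that bear on this change are the two that also swap the aryl group on the saturated ring carbon, from compound 1 to compound 2 and from compound 1 to compound 3, and both were within the scatter. No step beyond the scatter in this assay is therefore expected from this change, in either direction. Compound 4 is expected at 300000 nM, with a range from 150000 nM to 600000 nM. The expected step is a 1.1-fold lower number from compound 1 to compound 4 (0.02 log units; within the scatter).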

Compound 4, half-maximal cytotoxic concentration: 237000 nM
Compound 4: middle estimate off by 1.3-fold (0.10 log units), on the high side; the range from low to high includes it.
By their numbers in this assay, from the lowest: compounds 2, 4, 1 and 3 (each within the scatter of the next, the first and the last beyond it).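

Moving the methyl from 2-methylphenyl to 3-methylphenyl keeps the same atoms and changes only their joining, and in this assay this gives no readable change at this position (a 1.3-fold lower number from compound 1 to compound 4 (0.13 log units; within the scatter)). Going by these compounds alone, the 3-methylphenyl compound also stays within the scatter of both halogen-bearing compounds (a 1.5-fold lower number from compound 3 to compound 4 (0.19 log units; within the scatter); a 1.3-fold higher number from compound 2 to compound 4 (0.12 log units; within the scatter)), the second of these steps being methyl in place of chloro on an aromatic carbon, so the only step beyond the scatter remains the modest one (a 2.1-fold higher number from compound 2 to compound 3 (0.31 log units; beyond the scatter)). No measurement at hand speaks to what underlies these numbers.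

The aryl groups shown carry only a methyl, chloro or bromo. As far as these compounds go, whether an amine or a carboxylic acid on this phenyl ring, or a longer chain in place of the methyl, would move the number beyond the scatter stays open.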